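This account rests on a few compounds, and the source may have more. Where it says the series, first, only, none or still open, it means among the compounds named here.

Measured so far in an assay on LtK cells with ATP-sensitive inward rectifier potassium channel 11 (Homo sapiens) as the target; a lower number here means that less compound is needed, a higher number that more compound is needed for the effect:
- compound 1 `CC(C)CCC(=O)Nc1c(C(O)(C(F)(F)F)C(F)(F)F)ccc2ccccc12` gives 49 nM
- compound 2 `O=C(CCc1ccccc1)Nc1c(C(O)(C(F)(F)F)C(F)(F)F)ccc2ccccc12` gives 1750 nM
- compound 3 `O=C(Nc1c(C(O)(C(F)(F)F)C(F)(F)F)ccc2ccccc12)c1ccc(Br)cc1` gives 47 nM

Compound 3 has the lowest of the three numbers, but the step of a 1.0-fold lower number from compound 1 to compound 3 (0.02 log units; within the scatter) is within the scatter, so the two cannot be told apart on these data. Compound 2 is the one that stands apart: the step of a 36-fold higher number from compound 1 to compound 2 (1.55 log units; beyond the scatter) is large, and the return a 37-fold lower number from compound 2 to compound 3 (1.57 log units; beyond the scatter) is just as large in the other direction. All three share the same core, and differ only in the group on the carbonyl carbon of the amide.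

Compound 4 `O=C(Nc1c(C(O)(C(F)(F)F)C(F)(F)F)ccc2ccccc12)c1ccc(C(F)(F)F)cc1` is the next step from compound 3. The change is trifluoromethyl in place of bromo on an aromatic carbon. For the measured compounds named here, none of the measured steps touches a substituent on that aromatic ring; the steps seen so far replace the whole group on the carbonyl carbon, so they say nothing direct about swapping one group on the ring for another. Compound 3 with a 4-bromophenyl and compound 1 with an isopentyl on the carbonyl carbon are within the scatter of each other, which suggests this position tolerates different groups. For compound 4 a step of about a 1.1-fold higher number from compound 3 to compound 4 (0.03 log units; within the scatter) in this assay is therefore expected, staying within the scatter. The estimate for compound 4 is 50 nM, with a range from 15 nM to 170 nM.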

Compound 4, half-maximal effective concentration: 160 nM
Compound 4: middle estimate off by 3.2-fold (0.51 log units), on the low side; measured number inside the range.
By their numbers in this assay, from the lowest: compounds 3 and 1 (each within the scatter of the next); then compound 4; then compound 2.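

In this assay, trifluoromethyl in place of bromo on the aromatic carbon para to a large group gives a 3.4-fold higher number from compound 3 to compound 4 (0.53 log units; beyond the scatter), the first sign that this place on the ring responds to the swap of one small group for another, even though the whole-group swap from isopentyl to 4-bromophenyl on the carbonyl carbon stayed within the scatter. That tolerance therefore has limits: 4-(trifluoromethyl)phenyl in place of isopentyl gives a 3.3-fold higher number from compound 1 to compound 4 (0.51 log units; beyond the scatter), while the same group in place of phenethyl still gives an 11-fold lower number from compound 2 to compound 4 (1.04 log units; beyond the scatter), so the new group costs far less than phenethyl does. Nothing available here gives a measured reason for the gap between bromo and trifluoromethyl.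

With only these two groups shown on the ring, it remains open how chloro, methoxy, an amine or a carboxylic acid at the same place would compare with bromo. On these data alone, it is also open whether a ring carrying one of these groups would fare better or worse than the isopentyl chain on the carbonyl carbon, or than a longer chain there.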